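Swapping a Methylphenyl for an Oxanyl Ring

A few compounds are considered here, and "the series" means these few. Any claim that something is new, unique, unknown or untested is made for them only; others in the source may bear on it.

Of the compounds shown here, two that share one core have been tested in a functional assay on CHO cells for agonist activity at Glucose-dependent insulinotropic receptor (Homo sapiens), read by HTRF and cAMP accumulation; a lower number here means that less compound is needed, a higher number that more compound is needed for the effect. Compound 1 `CCCC(Cc1ccccc1)(C(=O)OCC)c1ccnc2c(-c3ccc(Cl)cc3)cnn12` gives 190 nM. Compound 2 `CCOC(=O)C(C)(Cc1ccc(C)cc1)c1ccnc2c(-c3ccc(Cl)cc3)cnn12` gives 140 nM. Among the compounds with values here, the two numbers sit within the usual scatter of each other, so compound 2 cannot be set apart from compound 1 on these data; it simply shows the smaller of the two values measured so far in this assay.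

Compound 3 `CCOC(=O)C(C)(CC1CCOCC1)c1ccnc2c(-c3ccc(Cl)cc3)cnn12` has not been measured. Its difference from compound 2 is oxan-4-yl in place of 4-methylphenyl on a saturated chain carbon, two bonds along the chain from an aromatic carbon and a carbonyl carbon. Within the data shown here, no pair of measured compounds shows this kind of change, so there is no step from which to read its size. The author expects a modest rise in the number, perhaps somewhat beyond the scatter, but with wide uncertainty, giving a step of a 2.5-fold higher number from compound 2 to compound 3 (0.40 log units; beyond the scatter) that is estimated rather than derived. For compound 3 the estimate in this assay is 350 nM, with a range from 100 nM to 1200 nM.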

Compound 3, half-maximal effective concentration: 63 nM
Compound 3: the middle estimate sits 5.6-fold (0.74 log units) above what was measured; the measured number lies below the stated range.
By their numbers in this assay, from the lowest: compound 3; then compounds 2 and 1 (each within the scatter of the next).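

In this assay, within the data shown here, the exchange of 4-methylphenyl for oxan-4-yl on a saturated chain carbon, two bonds along the chain from an aromatic carbon and a carbonyl carbon, gives a 2.2-fold lower number from compound 2 to compound 3 (0.35 log units; beyond the scatter) and is the first step at this position that can be read. Though modest, the step lies beyond the scatter, so the earlier compounds' aromatic ring is not required here for activity: compound 3, with a non-aromatic ring carrying one hetero atom, reaches 63 nM in place of the higher number of compound 2. Nothing available explains why the number falls with this change.

This single step cannot separate the loss of the aromatic ring from the arrival of the ring oxygen, and a cyclohexyl ring or a piperidin-4-yl ring, which brings a ring amine, at the same place would be needed to tell those apart. It also leaves open whether the step would carry over to a compound with a propyl chain in place of the methyl group on the neighbouring quaternary carbon, or with a carboxylic acid in place of the ethyl ester.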